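This account rests on a few compounds, and the source may have more. Where it says the series, first, only, none or still open, it means among the compounds named here.

Three compounds share one core and differ only in the group carried on an aromatic carbon of the five-membered aromatic ring with three nitrogens. Compound 1 `OCc1cn(CCNc2nonc2/C(=N/O)Nc2ccc(F)c(Br)c2)nn1` gives 794 nM in an assay on isolated protein for inhibition of Indoleamine 2,3-dioxygenase 2 (Homo sapiens) (on this read-out lower numbers stand for stronger inhibition and higher numbers for weaker inhibition), compound 2 `CCCCc1cn(CCNc2nonc2/C(=N/O)Nc2ccc(F)c(Br)c2)nn1` gives 830 nM, and compound 3 `CCC(O)c1cn(CCNc2nonc2/C(=N/O)Nc2ccc(F)c(Br)c2)nn1` gives 947 nM. Compound 3 carries the highest of the three numbers, yet the steps of a 1.2-fold higher number from compound 1 to compound 3 (0.08 log units; within the scatter) and a 1.1-fold higher number from compound 2 to compound 3 (0.06 log units; within the scatter) show that its value sits within the usual spread of the others, as does a 1.0-fold higher number from compound 1 to compound 2 (0.02 log units; within the scatter).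

Compound 4 `O/N=C(\Nc1ccc(F)c(Br)c1)c1nonc1NCCn1cc(C2(O)CCCCC2)nn1` continues this series: 1-hydroxycyclohexyl in place of 1-hydroxypropyl on an aromatic carbon. Within the data shown here, the steps that bear on this change are the ones at the same aromatic carbon, and each of them left the number within the scatter, whether a hydroxy became propyl, a hydrogen became ethyl, or butyl became 1-hydroxypropyl. Nothing measured here points to a larger group at this carbon moving the number. The expectation is therefore a step of a 1.0-fold higher number from compound 3 to compound 4 (0.00 log units; within the scatter), that is, no change beyond the scatter. For compound 4 the estimated value is 950 nM, expected between 450 nM and 2000 nM.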

Compound 4, half-maximal inhibitory concentration: 865 nM
Compound 4: the middle estimate sits 1.1-fold (0.04 log units) above what was measured; the measured number falls inside the stated range.
By their numbers in this assay, from the lowest: compounds 1, 2, 4 and 3 (each within the scatter of the next).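

Compound 4 is the first of these compounds to carry a ring on this aromatic carbon, a six-membered non-aromatic ring of carbon only, yet its number stays within the scatter of all three others (a 1.1-fold lower number from compound 3 to compound 4 (0.04 log units; within the scatter); a 1.0-fold higher number from compound 2 to compound 4 (0.02 log units; within the scatter); a 1.1-fold higher number from compound 1 to compound 4 (0.04 log units; within the scatter)). Replacing 1-hydroxypropyl with the larger 1-hydroxycyclohexyl therefore leaves the read-out unchanged, so across these four compounds neither a ring nor the extra size at this position produces a measurable step. Nothing available gives a reason for this flat picture.

As far as these compounds go, whether an amine, a carboxylic acid or a phenyl ring on this carbon would also stay within the scatter remains open. From the compounds shown here alone, all four compounds share the same core, so it is also open whether this holds with another group in place of the bromine.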